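Removing a Pyrazole Methyl in Piperidine Carboxamide Inhibitors

This account rests on a few compounds, and the source may have more. Where it says the series, first, only, none or still open, it means among the compounds named here.

Two small compounds anchor this series. Compound 1 `Cc1cnn(C(=O)N2CCCCC2)c1` gives 9200 nM in an assay on membranes from brain for binding affinity to Monoglyceride lipase (Mus musculus), read by fluorescence, with stated times of 1 h and 30 min (a lower number here means a stronger inhibitor, a higher number a weaker inhibitor), and compound 2 `O=C(N1CCCCC1)n1cccn1` gives 6600 nM in this assay. The step between them, a 1.4-fold lower number from compound 1 to compound 2 (0.14 log units; within the scatter), comes from a single change, (hydrogen in place of methyl on an aromatic carbon).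

Compound 3 `Cc1cnn(C(=O)N(C)CCN(C)Cc2ccc(OCc3ccccc3)cc2)c1` carries a much larger substituent on the carboxamide nitrogen and gives 1200 nM in this assay, the lowest of the three numbers. The difference between the core of compound 1 and the core of compound 3 is not broken down here.

Compound 4 `CN(CCN(C)C(=O)n1cccn1)Cc1ccc(OCc2ccccc2)cc1` has not yet been measured. It relates to compound 3 through (hydrogen in place of methyl on an aromatic carbon). Within the data shown here, the place differs only in that the ring atom nearby bears a large group rather than a group of 8 heavy atoms, so this is the same kind of change as the one from compound 1 to compound 2. Beside a 1.4-fold lower number from compound 1 to compound 2 (0.14 log units; within the scatter), the step from compound 3 to compound 4 is expected to be a 1.4-fold lower number from compound 3 to compound 4 (0.15 log units; within the scatter), resting on the earlier step alone. Compound 4 is therefore estimated at 850 nM, most likely between 400 nM and 2500 nM.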

Compound 4, half-maximal inhibitory concentration: 660 nM
For compound 4 the middle estimate is 1.3-fold (0.11 log units) above the measured one; measured number inside the range.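

Removing the methyl, which turns the 4-methyl-1H-pyrazol-1-yl group of compound 3 into the 1H-pyrazol-1-yl group of compound 4, gives a 1.8-fold lower number from compound 3 to compound 4 (0.26 log units; within the scatter) in this assay. Set beside the same change on the smaller core, the two steps cannot be told apart: the same change on two cores in this assay, a 1.4-fold lower number (0.14 log units; within the scatter) from compound 1 to compound 2 and a 1.8-fold lower number (0.26 log units; within the scatter) from compound 3 to compound 4, 1.3-fold (0.12 log units) apart, within the scatter of two such steps. So in this series, the change carries from one core to the other with a similar small effect on the number, and neither step can be separated from ordinary repeat-to-repeat variation; two pairs do not show that the step would stay this small on any further core, nor do they explain why it is small.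

The compounds shown hold only methyl or hydrogen at this ring carbon, so the effect of a chlorine atom, an ethyl group or a methoxy group there remains open. Also open, going by these compounds, is how compound 4 would respond to a longer chain within the large group on its carboxamide nitrogen.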